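Series notes: aryl substitution on the ring nitrogen

The source may report more compounds than this note shows. Statements on the series, on what has been measured and on what is new or still open speak of the compounds shown alone.

Compound 1 `Cc1ccc(-c2cc(/N=C3/NC(=O)CS3)cs2)cc1`, compound 2 `COc1ccc(-c2cc(/N=C3/NC(=O)CS3)cs2)cc1` and compound 3 `O=C1CS/C(=N\c2csc(-c3ccccc3)c2)N1` share one core and differ only in the substituent on the pendant aromatic carbon. In a functional assay on HT-29 cells (Homo sapiens) for cytotoxicity, read by MTT assay, with a stated time of 72 h (a lower number here means a stronger inhibitor, a higher number a weaker inhibitor), compound 1 gives only a limit, > 50000 nM. Compound 2 also gives a limit in this assay, > 50000 nM. Compound 3 stands at a limit in this assay as well, > 50000 nM. All three values sit at the limit of > 50000 nM in this assay, at which 3 of the 3 values shown sit, so the steps a step that the two limits leave unreadable from compound 1 to compound 2, a step that the two limits leave unreadable from compound 1 to compound 3 and a step that the two limits leave unreadable from compound 2 to compound 3 cannot be read in size or direction.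

Compound 4 `COc1cccc(N2C(=O)CS/C2=N\c2csc(-c3ccccc3)c2)c1` differs from compound 3 by 3-methoxyphenyl in place of hydrogen on an amide-type nitrogen in a ring. None of the three measured steps touches the ring nitrogen; they concern the substituent on the aromatic carbon and are unreadable besides, so they give no guide to the size or direction of the change in this assay. The step of an at least 1.2-fold lower number from compound 3 to compound 4 (0.09 log units; that floor lies within the scatter) is therefore expected to be uncertain, with a limit again the most likely outcome. Compound 4 is estimated at 40000 nM in this assay, within 5000 nM to 100000 nM.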

Compound 4, half-maximal inhibitory concentration: 38300 nM
For compound 4 the middle estimate is 1.0-fold (0.02 log units) above the measured one, within the range that was stated.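

In this assay the 3-methoxyphenyl on the amide-type nitrogen gives compound 4, the only compound shown with a value that is a number and not a limit: the limit of > 50000 nM in this assay, at which 3 of the 4 values shown sit. From the compounds shown here alone, the change shows as an at least 1.3-fold lower number from compound 3 to compound 4 (0.11 log units; that floor lies within the scatter) and, with compound 3 at a limit, the true size of the step stays unknown. The steps among compound 1, compound 2 and compound 3 on the pendant aromatic carbon cannot be read, so the ring nitrogen is the only place with a readable step.

Whether the step depends on the aromatic ring itself or on its methoxy stays open, as the compounds shown hold no unsubstituted phenyl, benzyl or short alkyl chain on this nitrogen. Also open, going by these compounds, is whether methyl or methoxy on the pendant aromatic carbon becomes readable with 3-methoxyphenyl in place.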